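Swapping the heteroaryl sulfanyl group on a shared core

The compounds below may be only part of what the source reports. "The series", "measured", "known", "first", "only" and "open" are said of these compounds alone.

Measured compounds:
compound 1 `Cn1c(-c2ccc(NC(=O)CSc3nc4cc(Cl)ccc4o3)cc2)nc(-c2ccccc2)c1-c1ccccc1` gives 27.7% in a functional assay on MCF7 cells (Homo sapiens) for cytotoxicity, read by MTT assay, with a stated time of 24 h, tested at 6.4 ug/mL; on this read-out lower numbers stand for a weaker effect and higher numbers for a stronger effect at the one concentration tested
compound 2 `Cn1nnnc1SCC(=O)Nc1ccc(-c2nc(-c3ccccc3)c(-c3ccccc3)n2C)cc1` gives 55.9% in this assay

Among the measured compounds shown here, compound 2 stands highest of the two numbers; the only measured step is a number 28.2 percentage points higher from compound 1 to compound 2 (beyond the scatter), which moved the read-out upward when 1-methyl-1H-tetrazol-5-yl replaced 5-chloro-1,3-benzoxazol-2-yl on the sulfur. Compound 3 `Cc1nnc(SCC(=O)Nc2ccc(-c3nc(-c4ccccc4)c(-c4ccccc4)n3C)cc2)s1` has not yet been measured. It differs from compound 2 as follows: 5-methyl-1,3,4-thiadiazol-2-yl in place of 1-methyl-1H-tetrazol-5-yl on a sulfur. For the measured compounds named here, no measured step exchanges the tetrazole for the thiadiazole, so the single step from compound 1 to compound 2 bears on it only loosely, as a sign that the group on the sulfur matters. With the ring on the sulfur changed again, a downward step of a number 10.9 percentage points lower from compound 2 to compound 3 (beyond the scatter) is expected, close to the scatter. Compound 3 is therefore estimated at 45%, within 25% to 65%.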

Compound 3, a percentage reported as activity, at one concentration (the size of the read-out at that concentration, not a potency): 67.8%
Beside the measured number, compound 3's estimate is 22.8 percentage points below it, outside the stated range (above it).
By their numbers in this assay, from the lowest: compound 1; then compound 2; then compound 3.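

In this assay, 5-methyl-1,3,4-thiadiazol-2-yl in place of 1-methyl-1H-tetrazol-5-yl on the sulfur gives a number 11.9 percentage points higher from compound 2 to compound 3 (beyond the scatter), so even an exchange between two five-membered aromatic rings, neither with a net charge, moves the read-out. Against 5-chloro-1,3-benzoxazol-2-yl, the same group gives a number 40.1 percentage points higher from compound 1 to compound 3 (beyond the scatter), the largest of the steps at this position, and compound 3 stands highest of the three. No measurement offered here explains this order.

The compounds leave open whether the ring or its methyl group carries the gain, which an amine or a carboxylic acid in place of that methyl group could help to test. As far as these compounds go, a longer chain between the sulfur and the carbonyl also remains unexplored here, as does the effect of these groups at other concentrations.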